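Butylsulfanyl in place of sulfanyl on the shared core

The source may report more compounds than this note shows. Statements on the series, on what has been measured and on what is new or still open speak of the compounds shown alone.

Measured so far:
- compound 1, `O=C(CCl)Nn1c(S)nnc1COc1ccccc1C1=NOC(c2ccc(Cl)cc2Cl)C1`: 3.2 ug/mL
- compound 2, `C/C=C/Sc1nnc(COc2ccccc2C2=NOC(c3ccc(Cl)cc3Cl)C2)n1NC(=O)c1ccccc1`: "not determined" (no result reported)
- compound 3, `CCOC(=O)CSc1nnc(COc2ccccc2C2=NOC(c3ccc(Cl)cc3Cl)C2)n1NC(C)=O`: "not determined" (no result reported)

For the measured compounds named here, compound 1 is the only member of the series for which a number exists in an ADME assay (MDM cells, Homo sapiens) for cytotoxicity, read by resazurin assay, with a stated time of 3 days; on this read-out lower numbers stand for stronger inhibition and higher numbers for weaker inhibition. Within that assay compound 1 gives 3.2 ug/mL. In this assay, going by the values given here, compound 2 is recorded as "not determined" (no result reported) and compound 3 is recorded as "not determined" (no result reported), so there is nothing to set beside compound 1 and no step between measured compounds can be drawn.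

Compound 4, `CCCCSc1nnc(COc2ccccc2C2=NOC(c3ccc(Cl)cc3Cl)C2)n1NC(=O)CCl`, is the next entry for this assay. It differs from compound 1 in one place: butyl in place of hydrogen on a sulfur. The sulfur that carries a hydrogen in compound 1 carries a butyl chain in compound 4, with the rest of the core left as it stands.

Among the compounds with values here, with no measured pair to show how a change at this sulfur moves the read-out, the expectation for compound 4 can rest only on the value of compound 1. The step from compound 1 to compound 4 is expected to be small, a 1.1-fold lower number from compound 1 to compound 4 (0.03 log units; within the scatter), not clearly beyond the scatter in either direction. Compound 4 is accordingly estimated at 3 ug/mL, with a range from 1.2 ug/mL to 8 ug/mL.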

Compound 4, half-maximal inhibitory concentration: 2.8 ug/mL
Compound 4: middle estimate off by 1.1-fold (0.03 log units), on the high side; measured number inside the range.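

In this assay the series now has its first readable step at this sulfur, a 1.1-fold lower number from compound 1 to compound 4 (0.06 log units; within the scatter), and it lies within the usual scatter of repeated measurements. For this pair, butylsulfanyl in place of sulfanyl therefore brings no clear shift in the read-out in either direction, so the hydrogen on the sulfur can give way to a butyl chain without a change that can be told from the scatter. No measured finding in hand offers an explanation for this result.

Steps involving compound 2 and compound 3 cannot be read, so this one pair is the only information on changes at this sulfur, and it gives no trend across substituents. Still open, as far as these compounds go, is whether a longer chain, or a chain ending in an amine or a carboxylic acid, would stay within the scatter of compound 1 or move the read-out clearly away from it.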